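The source may hold more compounds than are shown below. What is called first, only, known or untested is meant among the compounds shown, and "the series" means these compounds.

The measured compounds:
compound 1, `CN(c1ccccc1)c1cnc(NCc2c(F)ccc3c2CCO3)n2cnnc12`, 55 mL.min-1.g-1;
compound 2, `CN(C)Cc1ccc(C(=O)Nc2cnc(NCc3c(F)ccc4c3CCO4)n3cnnc23)cc1`, 13 mL.min-1.g-1.

In an ADME assay on microsomes from liver (Homo sapiens) for metabolic stability, read by LC-MS, using NADPH, with stated times of 5 min and 30 min, tested at 1 uM (on this read-out higher numbers stand for fast clearance and lower numbers for slow clearance), compound 1 gives 55 mL.min-1.g-1, the higher of the two numbers recorded. Compound 2, `CN(C)Cc1ccc(C(=O)Nc2cnc(NCc3c(F)ccc4c3CCO4)n3cnnc23)cc1`, gives 13 mL.min-1.g-1 in this assay, a gap that lies beyond the usual scatter of repeated runs. Going by the values given here, compound 2 differs from compound 1 at more than one place, so the pair yields no single step; the two values show only that compound 1 is cleared faster in this assay.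

The compound not yet measured is compound 3, `CN(C(=O)c1ccccc1)c1cnc(NCc2c(F)ccc3c2CCO3)n2cnnc12`. It is reached from compound 1 by one change: benzoyl in place of phenyl on a nitrogen on an aromatic ring. Among the compounds with values here, no measured pair in this set follows the same change, so nothing here fixes its size or direction. The account therefore treats the step as open and expects a moderate move toward slower clearance, with a 1.6-fold lower number from compound 1 to compound 3 (0.20 log units; within the scatter) as the estimated step. In this assay compound 3 is expected to give about 35 mL.min-1.g-1, within a range from 15 mL.min-1.g-1 to 80 mL.min-1.g-1.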

Compound 3, intrinsic clearance in microsomes: > 300 mL.min-1.g-1
Compound 3: only a limit was reported (the forecaster's own chance of this, stated with the estimate: 5%); middle value at least 8.5-fold (0.93 log units) from the limit.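

In this assay, going by these compounds alone, benzoyl in place of phenyl on a nitrogen on an aromatic ring gives an at least 5.4-fold higher number from compound 1 to compound 3 (0.73 log units; beyond the scatter), the first step at this position that can be read, and it points toward faster clearance rather than slower. Compound 3 gives > 300 mL.min-1.g-1, which is a limit of the assay and not a number: the limit of > 300 mL.min-1.g-1 in this assay, at which 1 of the 3 values shown sits. The step therefore fixes a direction and a smallest size but no true size, and it shows that the number in this assay responds strongly to what this nitrogen carries, even when one group with a six-membered aromatic ring of carbon only replaces another.

The compounds shown leave open how far compound 3 lies past its limit, and whether the rise follows the carbonyl alone or the benzoyl group as a whole. They also give no reading of how a smaller acyl group such as acetyl, or a sulfonyl group such as methanesulfonyl, on this same nitrogen would behave in this assay.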